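Bromo in place of hydrogen on a naphthyl-bearing analogue

This account rests on a few compounds, and the source may have more. Where it says the series, first, only, none or still open, it means among the compounds named here.

Compound 1 `COc1ccc(C2CC(c3ccccc3)=NN2C2=NC(=O)/C(=C3\C(=O)Nc4ccc(Br)cc43)S2)cc1` — 240 nM
Compound 2 `COc1ccc(C2=NN(C3=NC(=O)/C(=C4\C(=O)Nc5ccc(Br)cc54)S3)C(c3ccc(OC)cc3)C2)cc1` — 270 nM
Compound 3 `COc1ccc(C2CC(c3ccc4ccccc4c3)=NN2C2=NC(=O)/C(=C3\C(=O)Nc4ccccc43)S2)cc1` — 360 nM

Of the compounds shown here, three sharing one core have been measured in a functional assay on cells (Cancer cell lines, Homo sapiens) for cytotoxicity, read by sulforhodamine B assay, with a stated time of 48 h; on this read-out lower numbers stand for stronger inhibition of growth and higher numbers for weaker inhibition of growth. Compound 1 gives 240 nM, compound 2 gives 270 nM and compound 3 gives 360 nM. Among these three, compound 3 carries the highest number, but its gap to compound 2 and to compound 1 lies within the scatter, so no order among them can be read. Among the measured compounds shown here, the single one-point step recorded, a 1.1-fold higher number from compound 1 to compound 2 (0.05 log units; within the scatter), likewise stays within the scatter.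

Compound 4 `COc1ccc(C2CC(c3ccc4ccccc4c3)=NN2C2=NC(=O)/C(=C3\C(=O)Nc4ccc(Br)cc43)S2)cc1` has not yet been measured. It differs from compound 3 in one place: bromo in place of hydrogen on an aromatic carbon. For the measured compounds named here, no measured pair shows exactly this change, so the only direct step, from compound 1 to compound 2, bears on it merely by showing how little a single substituent change moved this read-out here. Compounds 1 and 2, which carry the bromo group, gave numbers somewhat lower than compound 3, yet within the scatter.

Compound 4 is therefore expected to give a number close to that of compound 3, with a step of a 1.2-fold lower number from compound 3 to compound 4 (0.08 log units; within the scatter) that is not expected to exceed the scatter. The estimate for compound 4 in this assay is 300 nM, between 150 nM and 600 nM.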

Compound 4, concentration for 50% growth inhibition: 59 nM
For compound 4 the middle estimate is 5.1-fold (0.71 log units) above the measured one; measured number below the stated range.
By their numbers in this assay, from the lowest: compound 4; then compounds 1, 2 and 3 (each within the scatter of the next).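

In this assay, among the compounds shown here, bromo in place of hydrogen on an aromatic carbon of the six-membered aromatic ring of carbon only, part of a fused or bridged system of two rings, gives a 6.1-fold lower number from compound 3 to compound 4 (0.79 log units; beyond the scatter), so this position can move the read-out, which the single earlier step, a 1.1-fold higher number from compound 1 to compound 2 (0.05 log units; within the scatter), gave no sign of. With the bromo group kept in place, the other aryl position responds as well: naphthalen-2-yl in place of phenyl gives a 4.1-fold lower number from compound 1 to compound 4 (0.61 log units; beyond the scatter), and naphthalen-2-yl in place of 4-methoxyphenyl gives a 4.6-fold lower number from compound 2 to compound 4 (0.66 log units; beyond the scatter). Compound 4, with bromo and naphthalen-2-yl together, therefore has the lowest number of the four, and its steps to all three others lie beyond the scatter.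

Nothing available explains why these two changes give steps of this size, or whether the bromo step depends on the naphthalen-2-yl group. On these data alone, it remains open whether chloro, fluoro or a methyl group on the same aromatic carbon would give a similar step, and whether bromo would give one on a compound carrying phenyl rather than naphthalen-2-yl.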